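Swapping prop-1-en-1-yl for vinyl on a carbonyl carbon

The source may hold more compounds than are shown below. What is called first, only, known or untested is meant among the compounds shown, and "the series" means these compounds.

Compound 1 `C=CC(=O)N1CCCC(n2nc(-c3ccc(Oc4ccccc4)cc3)cc2C(=O)O)C1` gives > 60000 nM
Compound 2 `C=CC(=O)N1CCCC(n2nc(-c3ccc(Oc4ccccc4)cc3)cc2C(=O)OCC)C1` gives 44000 nM
Compound 3 `C/C=C/C(=O)N1CCCC(n2nc(-c3ccc(Oc4ccccc4)cc3)cc2CO)C1` gives 51100 nM

In a functional assay on Z-138 cells (Homo sapiens) for inhibition, read by luminescence and CellTiter-Glo, with a stated time of 72 h (on this read-out lower numbers stand for stronger inhibition and higher numbers for weaker inhibition), compound 1 reads > 60000 nM as a limit and not a number. Compound 2 at 44000 nM and compound 3 at 51100 nM sit within the usual scatter of each other, so compound 3 stands level with its nearest measured neighbour. Compound 4 `C=CC(=O)N1CCCC(n2nc(-c3ccc(Oc4ccccc4)cc3)cc2CO)C1` differs from compound 3 in one place vinyl in place of prop-1-en-1-yl on a carbonyl carbon with vinyl in place of prop-1-en-1-yl on a carbonyl carbon. Among the measured compounds shown here, no measured step makes this change. For the measured compounds named here, the only step available is an at least 1.3-fold lower number from compound 1 to compound 2 (0.13 log units; that floor lies within the scatter) and it concerns a different group, so it gives little guidance on size. A small shift in this assay is therefore expected, perhaps towards a lower number but not beyond the scatter. The estimated change is a 1.7-fold lower number from compound 3 to compound 4 (0.23 log units; within the scatter) for this swap. For compound 4 the expected value is 30000 nM with an estimated range of 8000 nM to 60000 nM in this measurement.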

Compound 4, half-maximal inhibitory concentration: 14600 nM
Beside the measured number, compound 4's estimate is 2.1-fold (0.31 log units) above it; measured number inside the range.
By their numbers in this assay, from the lowest: compound 4; then compounds 2 and 3 (each within the scatter of the next). At a limit, above all of these: compound 1.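

In this assay, among the compounds shown here, the group on this carbonyl carbon, whose other neighbour is an amide-type nitrogen in a ring, makes a clear difference: vinyl in place of prop-1-en-1-yl gives a 3.5-fold lower number from compound 3 to compound 4 (0.54 log units; beyond the scatter), whereas the floor of the only earlier step lay within the scatter. With vinyl in both partners, the group on the aromatic carbon counts too: hydroxymethyl in place of ethoxycarbonyl gives a 3.0-fold lower number from compound 2 to compound 4 (0.48 log units; beyond the scatter), and hydroxymethyl in place of carboxy gives an at least 4.1-fold lower number from compound 1 to compound 4 (0.61 log units; beyond the scatter). That last step is only a floor, as compound 1 reads as a limit and not a number: the limit of > 60000 nM in this assay, at which 1 of the 4 values shown sits.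

The compounds shown leave open how a longer chain on this carbonyl carbon, or one carrying an amine, would read. Also open, from the compounds shown here alone, is whether an amine or a primary amide in place of hydroxymethyl on the aromatic carbon would give a lower number than compound 4.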